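This account rests on a few compounds, and the source may have more. Where it says the series, first, only, none or still open, it means among the compounds named here.

In a functional assay on HCC1937 cells (Homo sapiens) for inhibition, read by MTT assay, with a stated time of 48 h (on this read-out lower numbers stand for stronger inhibition and higher numbers for weaker inhibition), compound 1 `CN1CCN(c2ncc3c(n2)CCN(C(=O)c2cc(Cc4n[nH]c(=O)c5ccccc45)ccc2F)C3)CC1` gives 53400 nM, and compound 2 `CCN1CCN(c2ncc3c(n2)CCN(C(=O)c2cc(Cc4n[nH]c(=O)c5ccccc45)ccc2F)C3)CC1` gives 137000 nM; the change between them is a 2.6-fold higher number from compound 1 to compound 2 (0.41 log units; beyond the scatter). Compound 3 `O=C(c1cc(Cc2n[nH]c(=O)c3ccccc23)ccc1F)N1CCc2nc(N3CCCCC3)ncc2C1` reaches only the limit > 200000 nM in this assay. Compound 3 therefore stands at the weak end of the three, at the limit (the limit of > 200000 nM in this assay, at which 1 of the 3 values shown sits). The steps onto compound 3 were an at least 3.7-fold higher number from compound 1 to compound 3 (0.57 log units; beyond the scatter) and an at least 1.4-fold higher number from compound 2 to compound 3 (0.16 log units; that floor lies within the scatter). Compound 4 `CCN(CC)c1ncc2c(n1)CCN(C(=O)c1cc(Cc3n[nH]c(=O)c4ccccc34)ccc1F)C2` carries diethylamino in place of piperidin-1-yl on an aromatic carbon. Among the measured compounds shown here, no measured step covers an open chain amine in this place, and the two steps onto compound 3 concern the piperazine ring rather than the piperidine, so no change beyond the scatter is expected for compound 4 in this assay, with a step that the limit leaves unreadable from compound 3 to compound 4. The estimate for compound 4 is 250000 nM, between 100000 nM and 600000 nM.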

Compound 4, half-maximal inhibitory concentration: 66800 nM
Beside the measured number, compound 4's estimate is 3.7-fold (0.57 log units) above it; measured number outside the range, below it.
By their numbers in this assay, from the lowest: compounds 1 and 4 (each within the scatter of the next); then compound 2. At a limit, above all of these: compound 3.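

In this assay, the open chain diethylamino group gives a measured number where the piperidin-1-yl ring reached only a limit, with an at least 2.9-fold lower number from compound 3 to compound 4 (0.47 log units; beyond the scatter). The size of that step is only a floor, since compound 3 stands at a limit: the limit of > 200000 nM in this assay, at which 1 of the 4 values shown sits. Diethylamino also stays level with 4-methylpiperazin-1-yl, with a 1.3-fold higher number from compound 1 to compound 4 (0.10 log units; within the scatter), and gives a lower number than 4-ethylpiperazin-1-yl, with a 2.1-fold lower number from compound 2 to compound 4 (0.31 log units; beyond the scatter), so a piperazine ring is not required for a measured number at this position.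

The compounds shown leave open whether dimethylamino, pyrrolidin-1-yl or morpholin-4-yl would follow diethylamino or piperidin-1-yl here.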